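The compounds below may be only part of what the source reports. "The series", "measured", "known", "first", "only" and "open" are said of these compounds alone.

In an ADME assay on MT4 cells (Homo sapiens) for cytotoxicity, read by MTT assay (on this read-out lower numbers stand for higher toxicity in this test and higher numbers for lower toxicity in this test), compound 2 (`Cc1ccc(N(C(=O)c2cccc([N+](=O)[O-])c2)C(=S)OCCN2C(=O)c3ccccc3C2=O)cc1`) gives 100000 nM and compound 3 (`Cc1ccc(C(=O)N(C(=S)OCCN2C(=O)c3ccccc3C2=O)c2ccc(C)cc2)cc1`) gives 83000 nM as its number, so these two sit level at the top of this small set. Compound 1 (`O=C1c2ccccc2C(=O)N1CCOC(=S)N(C(=O)c1cccc([N+](=O)[O-])c1)c1ccc(Cl)cc1`) stands clearly lower, with 18000 nM as its result.

Compound 4 (`O=C1c2ccccc2C(=O)N1CCOC(=S)N(C(=O)c1cccc([N+](=O)[O-])c1)c1c(Cl)cccc1Cl`) has not been measured. Its difference from compound 2 is 2,6-dichlorophenyl in place of 4-methylphenyl on an amide-type nitrogen in full, which means 2,6-dichlorophenyl in place of 4-methylphenyl on an amide-type nitrogen.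

Two measured steps can be weighed. The step of a 1.2-fold lower number from compound 2 to compound 3 (0.08 log units; within the scatter) is within the scatter and concerns the group on the carbonyl carbon, so it offers little guidance here. The step of a 5.6-fold higher number from compound 1 to compound 2 (0.74 log units; beyond the scatter) is modest but beyond the scatter, and it is methyl in place of chloro on an aromatic carbon. Read backwards, it links a chlorine-bearing group with the lower number.

In this assay, for the measured compounds named here, a drop of similar size is therefore expected on leaving compound 2, although no measured compound carries 2,6-dichlorophenyl and the evidence is one step only. The expected change is a 3.3-fold lower number from compound 2 to compound 4 (0.52 log units; beyond the scatter) by this estimate. For compound 4 the estimated value is 30000 nM with an expected range from 7000 nM to 110000 nM in this test.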

Compound 4, half-maximal cytotoxic concentration: 58000 nM
Estimate against measurement, compound 4: 1.9-fold (0.29 log units) below; measured number inside the range.
By their numbers in this assay, from the lowest: compound 1; then compounds 4, 3 and 2 (each within the scatter of the next).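

In this assay, for the compounds shown here, the amide-type nitrogen tolerates a larger change than the earlier compounds had tested, with a 1.7-fold lower number from compound 2 to compound 4 (0.24 log units; within the scatter) when 2,6-dichlorophenyl takes the place of 4-methylphenyl, so these two groups cannot be told apart in this test. The second comparison keeps everything else fixed and gives a 3.2-fold higher number from compound 1 to compound 4 (0.51 log units; beyond the scatter) on exchanging 4-chlorophenyl for 2,6-dichlorophenyl, so chlorine on this ring does not by itself go with the low number seen for compound 1; what counts here is which chlorine-bearing group is present, and compound 4 is the compound that breaks the earlier link between chlorine and a lower number. Nothing available explains why these two chlorine-bearing groups differ.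

Going by these compounds, every group on this nitrogen so far is a substituted phenyl ring, so it remains open how a plain phenyl, a pyridine ring or a cyclohexyl group would behave there. On these data alone, it is also open whether the gap between 4-chlorophenyl and 2,6-dichlorophenyl would persist with 4-methylphenyl rather than 3-nitrophenyl on the carbonyl carbon.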